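A hydroxyethyl piperidine replaces the carbamoylmethyl piperazine

The source may hold more compounds than are shown below. What is called first, only, known or untested is meant among the compounds shown, and "the series" means these compounds.

Compound 1 `NC(=O)CC1CCN(c2nc(-c3cc(F)c(Cl)cc3F)nc3c2CS(=O)(=O)C3)CC1`: 8.3 nM
Compound 2 `NC(=O)CCC1CCN(c2nc(-c3cc(F)c(Cl)cc3F)nc3c2CS(=O)(=O)C3)CC1`: 18 nM
Compound 3 `NC(=O)CN1CCN(c2nc(-c3cc(F)c(Cl)cc3F)nc3c2CS(=O)(=O)C3)CC1`: 44 nM

These three compounds share one core and were tested in a functional assay on HEK293 cells for agonist activity at Glucose-dependent insulinotropic receptor (Homo sapiens), read by reporter gene assay and cAMP accumulation, with a stated time of 6 h; a lower number here means that less compound is needed, a higher number that more compound is needed for the effect. Compound 3 has the highest number of the three, above compound 2 and well above compound 1. Compound 4 `O=S1(=O)Cc2nc(-c3cc(F)c(Cl)cc3F)nc(N3CCC(CCO)CC3)c2C1` is not yet measured; its change from compound 3 is 4-(2-hydroxyethyl)piperidin-1-yl in place of 4-(carbamoylmethyl)piperazin-1-yl on an aromatic carbon. Among the measured compounds shown here, two measured steps bear on this. The step of a 5.3-fold higher number from compound 1 to compound 3 (0.72 log units; beyond the scatter) concerns the same ring swap, in the opposite direction, so restoring the 4-substituted piperidin-1-yl should lower the number. The step of a 2.2-fold higher number from compound 1 to compound 2 (0.34 log units; beyond the scatter) shows that altering the chain on that ring shifts the number only modestly. For the measured compounds named here, no measured pair covers the exchange of carbamoylmethyl for 2-hydroxyethyl, so the range is kept wide. Compound 4 is expected to show a step of a 2.9-fold lower number from compound 3 to compound 4 (0.47 log units; beyond the scatter), because a 5.3-fold higher number from compound 1 to compound 3 (0.72 log units; beyond the scatter) is being reversed. Compound 4 is therefore estimated at 15 nM, within 5 nM to 50 nM.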

Compound 4, effective concentration (reported as EC, without a stated level of effect): 2.8 nM
For compound 4 the middle estimate is 5.4-fold (0.73 log units) above the measured one; the measured number lies below the stated range.
By their numbers in this assay, from the lowest: compound 4; then compound 1; then compound 2; then compound 3.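

In this assay, among the compounds shown here, placing 4-(2-hydroxyethyl)piperidin-1-yl on this aromatic carbon gives the largest step so far, a 16-fold lower number from compound 3 to compound 4 (1.20 log units; beyond the scatter). The end of the chain matters as well as the ring: with the piperidine ring kept, hydroxy in place of carbamoyl still gives a 6.4-fold lower number from compound 2 to compound 4 (0.81 log units; beyond the scatter), and the shorter carbamoyl chain gives a 3.0-fold lower number from compound 1 to compound 4 (0.47 log units; beyond the scatter). No measurement at hand gives a reason for these gains.

Open, as far as these compounds go, is whether a methoxy group or an amine at the chain end, or a longer chain ending in hydroxy, would keep this level. Also open, from the compounds shown here alone, is how a 4-(2-hydroxyethyl)piperazin-1-yl group would compare.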